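Furan-2-yl to furan-3-yl on the shared core

The compounds below may be only part of what the source reports. "The series", "measured", "known", "first", "only" and "open" are said of these compounds alone.

In a functional assay on CEM-DNR-bulk cells (Homo sapiens), read by MTT assay, with a stated time of 72 h (a lower number here means a stronger inhibitor, a higher number a weaker inhibitor), compound 1 `C#Cc1cn([C@@H]2O[C@H](CO)[C@@H](O)[C@H]2O)c2nc(C)nc(N)c12` gives 12600 nM. Compound 2 `Nc1nc2c(c(-c3ccco3)cn2[C@@H]2O[C@H](CO)[C@@H](O)[C@H]2O)c(=O)[nH]1` stands at > 20000 nM, which is a limit of the assay and not a number. Compound 3 `Nc1nc2c(c(-c3ccoc3)cn2[C@@H]2O[C@H](CO)[C@@H](O)[C@H]2O)c(=O)[nH]1` carries furan-3-yl in place of furan-2-yl on an aromatic carbon. Within the data shown here, no measured pair in this assay shows a change of this kind, so no direction is favoured and nothing beyond the scatter is expected. The expected size is a number no higher from compound 2 to compound 3 (the limit leaves the size open). In this assay the estimate for compound 3 is 20000 nM, with an expected range of 7000 nM to 40000 nM.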

Compound 3, half-maximal inhibitory concentration: 15000 nM
For compound 3 the middle estimate is 1.3-fold (0.12 log units) above the measured one, within the range that was stated.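

In this assay, moving the attachment from furan-2-yl to furan-3-yl gives the first step read at this position: an at least 1.3-fold lower number from compound 2 to compound 3 (0.12 log units; that floor lies within the scatter). Among these compounds, compound 3 also gives the first measured number for a furan on this shared core. Compound 2 stands at > 20000 nM, a limit of the assay and not a number, so the full size of the step stays unread because of that limit: the limit of > 20000 nM in this assay, at which 1 of the 3 values shown sits.

Open, on these data alone, is whether a group other than furan on this aromatic carbon, such as an amine, a carboxylic acid or a longer chain, would move the number beyond the scatter.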